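Opening the amino substituent of compound 3

The source may report more compounds than this note shows. Statements on the series, on what has been measured and on what is new or still open speak of the compounds shown alone.

Three analogues share one core and have been measured in a functional assay on NCI-H460 cells (Homo sapiens) for cytotoxicity, read by sulforhodamine B assay, with a stated time of 48 h; on this read-out higher numbers stand for an effect only at larger amounts of compound and lower numbers for an effect already at smaller amounts. Compound 1 `CCN(CC)c1ccc(/C=C2/SC(Nc3ccccc3)=NC2=O)cc1` gives 6900 nM in this assay. For compound 2 `CCN(CC)c1ccc(/C=C2/SC(N(c3ccccc3)c3ccccc3)=NC2=O)cc1` this assay reports only a limit, > 100000 nM. Among the compounds with values here, the one measured step, an at least 14-fold higher number from compound 1 to compound 2 (1.16 log units; beyond the scatter), is a large one. Compound 3 `CN(C)c1ccc(/C=C2/SC(N(C)c3ccccc3)=NC2=O)cc1` gives 80 nM in this assay, the lowest of the two numbers available, with compound 1 standing far higher.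

The compound now in question, compound 4 `CCN(CC)c1ccc(/C=C2/SC(N(C)c3ccccc3)=NC2=O)cc1`, differs from compound 3 in one place: diethylamino in place of dimethylamino on an aromatic carbon. Compound 1 and compound 2 already carry the diethylamino group, so that group by itself does not fix the outcome; their own step concerns a different position and says nothing direct about the change from compound 3 to compound 4. Within the data shown here, no measured pair shows the dimethylamino-to-diethylamino exchange on this core, so there is no step of known size to lean on.

With no evidence either way, the step in this assay is expected to stay within the usual scatter or a little beyond it; the author expects compound 4 to give an estimate of 150 nM, within 40 nM to 600 nM, which corresponds to an expected step of a 1.9-fold higher number from compound 3 to compound 4 (0.27 log units; within the scatter).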

Compound 4, half-maximal effective concentration: 280 nM
The estimate for compound 4 lay 1.9-fold (0.27 log units) below the measured number, and the stated range covers the measured number.
By their numbers in this assay, from the lowest: compound 3; then compound 4; then compound 1. At a limit, above all of these: compound 2.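

In this assay, the exchange of dimethylamino for diethylamino on the aromatic carbon now has a measured size on the shared core: a 3.5-fold higher number from compound 3 to compound 4 (0.54 log units; beyond the scatter) is a modest step, though beyond the scatter, and it shows that this position tolerates the larger group with only a limited rise in the number. With diethylamino held constant, the substituent on the other nitrogen matters far more, as a 25-fold lower number from compound 1 to compound 4 (1.39 log units; beyond the scatter) shows for methyl in place of hydrogen, making compound 4 the lowest of the three diethylamino compounds. The step for methyl in place of phenyl, an at least 350-fold lower number from compound 2 to compound 4 (2.55 log units; beyond the scatter), is also large, but compound 2 stands only at a limit, so its full size cannot be read: the limit of > 100000 nM in this assay, at which 1 of the 4 values shown sits.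

The compounds shown leave open whether the exchange on the aromatic carbon would have the same size with hydrogen or phenyl on the other nitrogen. They also do not show how an ethyl group on that nitrogen, or a morpholine or a longer chain in place of diethylamino, would fare.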